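The compounds below may be only part of what the source reports. "The series", "measured", "known", "first", "only" and "open" are said of these compounds alone.

Compound 1 `Nc1nc(=O)n([C@@H]2CS[C@@H](CO)O2)cc1Br`: > 100000 nM (a limit)
Compound 2 `Nc1nc(F)nc2c1ncn2[C@@H]1CS[C@@H](CO)O1`: 45400 nM
Compound 3 `CNc1ncnc2c1ncn2[C@H]1CS[C@@H](CO)O1`: > 100000 nM (a limit)

All three compounds were tested in a functional assay on Vero cells (Chlorocebus sabaeus) for inhibition; a lower number here means a stronger inhibitor, a higher number a weaker inhibitor. Compound 1 has no number of its own there. Its reading of > 100000 nM is a limit. That places compound 1 in the larger group on these data, (the limit of > 100000 nM in this assay, at which 2 of the 3 values shown sit). Compound 3 is the other member of that group. Compound 2 is the only one of the three to return a number.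

The next compound, compound 4 `Cc1cn([C@@H]2CS[C@@H](CO)O2)c(=O)nc1N`, has methyl in place of bromo on an aromatic carbon, (methyl in place of bromo on an aromatic carbon). Within the data shown here, no measured pair here shows what such a change does, so the expectation rests on compound 1 alone, and that compound offers only a limit. The step expected in this assay is none beyond the scatter, and no direction can be favoured: a number no higher from compound 1 to compound 4 (the limit leaves the size open) is the estimated step. For compound 4 the estimated value is 100000 nM, with an expected range of 30000 nM to 300000 nM.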

Compound 4, half-maximal inhibitory concentration: > 100000 nM
Compound 4: a limit, no number; the forecaster's own chance of this, stated with the estimate: 65%; the middle value lies on the limit itself.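

Compound 4, like compound 1, gives only a limit and no number, so no step can be read between compound 1 and compound 4. What methyl in place of bromo on an aromatic carbon does to inhibition stays open, and most readings share one limit: the limit of > 100000 nM in this assay, at which 3 of the 4 values shown sit.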